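Shifting carboxylic acid and fluorine on the distant ring

The source may report more compounds than this note shows. Statements on the series, on what has been measured and on what is new or still open speak of the compounds shown alone.

Three compounds of this study share one core, shown here as compound 1, `Cc1c(OCCCCOc2ccccc2C(=O)O)ccc(C(=O)CC2CCCC2)c1C`, compound 2, `Cc1c(OCCCCOc2ccc(C(=O)O)cc2F)ccc(C(=O)CC2CCCC2)c1O`, and compound 3, `Cc1c(OCCCCOc2ccc(C(=O)O)cc2F)ccc(C(=O)CC(C)C)c1O`. In an assay on HEK293 cells for positive allosteric modulation of metabotropic glutamate receptor 3 (Rattus norvegicus), read by thallium flux, with a stated time of 2.5 min (a lower number here means that less compound is needed, a higher number that more compound is needed for the effect), compound 1 gives "not determined" (no result reported). In this assay compound 2 reaches only a limit, > 10000 nM. Compound 3 gives 1420 nM, the only number shown in this assay. Among the measured compounds shown here, the single measured step, an at least 7.0-fold lower number from compound 2 to compound 3 (0.84 log units; beyond the scatter), is the change from cyclopentyl to isopropyl on a saturated chain carbon bound to a carbonyl carbon; it starts from a compound that sits at the limit of > 10000 nM in this assay, at which 1 of the 3 values shown sits, so its true size is not known.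

Compound 4, `Cc1c(OCCCCOc2ccc(F)c(C(=O)O)c2)ccc(C(=O)CC(C)C)c1O`, has the same atoms as compound 3 joined differently: 3-carboxy-4-fluorophenyl in place of 4-carboxy-2-fluorophenyl on an oxygen on a saturated carbon. For the measured compounds named here, no measured step touches this part of the molecule; the only step known concerns the chain at the other end. There is therefore no ground to expect a change beyond the scatter, and the estimate for compound 4 rests on compound 3 alone. Compound 4 is expected to give about 1400 nM, within 350 nM to 6000 nM, which means an expected step of a 1.0-fold lower number from compound 3 to compound 4 (0.01 log units; within the scatter).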

Compound 4, half-maximal effective concentration: 920 nM
Compound 4: the middle estimate sits 1.5-fold (0.18 log units) above what was measured; low and high end bracket the measured number.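

Swapping 4-carboxy-2-fluorophenyl for 3-carboxy-4-fluorophenyl on an oxygen on a saturated carbon gives a 1.5-fold lower number from compound 3 to compound 4 (0.19 log units; within the scatter) in this assay. Among the compounds shown here, this is the first measured step at this end of the molecule, since the earlier step concerned only the chain at the other end, and it shows that the carboxylic acid and the fluorine can be arranged on this ring in either of these two ways without a change that can be told from ordinary scatter, so compound 3 and compound 4 cannot be ranked against each other. Nothing measured for these compounds explains why the two arrangements read alike, and a close match of this kind says only that this one rearrangement leaves the number in place, not that the ring's groups are unimportant.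

The compounds shown leave open whether the carboxylic acid is needed at all, which a primary amide or a tetrazole on the same ring would test, and whether the fluorine matters, which a plain hydrogen in its place would test. They also leave open how a longer chain linking the two ring oxygens would read in this assay.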